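A few compounds are considered here, and "the series" means these few. Any claim that something is new, unique, unknown or untested is made for them only; others in the source may bear on it.

The measured compounds, all tested in an in vitro functional assay on cells for agonist activity at Bombesin receptor subtype-3 (Homo sapiens), read by luminescence and calcium flux; a lower number here means that less compound is needed, a higher number that more compound is needed for the effect:
compound 1 `O=C(O)c1ccccc1-c1ccc(CCc2ncc(CCC3CCCCC3)[nH]2)cc1`, where compound 1 gives 642 nM
compound 2 `O=C(O)c1ccccc1-c1ccc(CCc2ncc(CC3CCOCC3)[nH]2)cc1`, where compound 2 gives 338 nM
compound 3 `O=C(O)c1ccccc1-c1ccc(CCc2ncc(CC3CCCCC3)[nH]2)cc1`, where compound 3 gives 41 nM

Compound 2 stands second highest of the three numbers. Its nearest neighbour is compound 1, with a 1.9-fold lower number from compound 1 to compound 2 (0.28 log units; within the scatter); its furthest is compound 3, with an 8.2-fold lower number from compound 2 to compound 3 (0.92 log units; beyond the scatter). The three compounds share one core and differ only in the group on a saturated chain carbon bound to an aromatic carbon.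

Compound 4 `CC(C)(C)Cc1cnc(CCc2ccc(-c3ccccc3C(=O)O)cc2)[nH]1` has not yet been measured. It arises from compound 2 by the change (tert-butyl in place of oxan-4-yl on a saturated chain carbon bound to an aromatic carbon).

Going by the values given here, two measured steps bear on this. The step from compound 2 to compound 3 also removes the oxan-4-yl group, replacing it with a ring of carbon only, and gives an 8.2-fold lower number from compound 2 to compound 3 (0.92 log units; beyond the scatter). The step from compound 1 to compound 3 shows that a shorter link to the ring helps, with a 16-fold lower number from compound 1 to compound 3 (1.19 log units; beyond the scatter). Compound 4 keeps a carbon-only group but has no ring at all, so the gain seen with compound 3 is expected only in part. The expected step is a 2.8-fold lower number from compound 2 to compound 4 (0.45 log units; beyond the scatter), a lowering in this assay beyond the scatter but short of what compound 3 reached.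

Compound 4 is estimated at 120 nM, in the range 40 nM to 400 nM.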

Compound 4, half-maximal effective concentration: 106 nM
The estimate for compound 4 lay 1.1-fold (0.05 log units) above the measured number; the range from low to high includes it.
By their numbers in this assay, from the lowest: compound 3; then compound 4; then compounds 2 and 1 (each within the scatter of the next).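

Compound 4 shows that this position does not need a ring for a number well under that of compound 2: in this assay, tert-butyl, with no ring, no oxygen and fewer heavy atoms than oxan-4-yl, gives a clear drop (a 3.2-fold lower number from compound 2 to compound 4 (0.50 log units; beyond the scatter)). The ring-bearing groups now fall on either side of tert-butyl, with cyclohexyl still ahead of it (a 2.6-fold higher number from compound 3 to compound 4 (0.41 log units; beyond the scatter)) and cyclohexylmethyl well behind it (a 6.1-fold lower number from compound 1 to compound 4 (0.78 log units; beyond the scatter)), so having a ring does not by itself set the number, and among these compounds neither the smallest group nor the largest gives the lowest one. Nothing available here explains why the four groups fall in this order.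

The compounds shown leave open how far the carbon-only group can shrink or change shape, for instance whether isopropyl or cyclopentyl on the same saturated chain carbon would stay close to compound 3 or drift towards compound 4. They also leave open whether a ring carrying an amine, such as piperidin-4-yl, would behave like oxan-4-yl or like cyclohexyl.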